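The source may hold more compounds than are shown below. What is called first, only, known or untested is meant among the compounds shown, and "the series" means these compounds.

Measured compounds in the series:

compound 1 `O=[N+]([O-])c1cncc(OC[C@@H]2CCN2)c1`: 0.33 nM
compound 2 `Clc1ncccc1OC[C@@H]1CCN1`: 2.3 nM
compound 3 `Cc1ncccc1OC[C@@H]1CCN1`: 1.36 nM

In an assay on brain for binding affinity to Neuronal acetylcholine receptor; alpha4/beta2 (Rattus norvegicus), read by radioligand binding (a higher number here means a weaker inhibitor, a lower number a stronger inhibitor), compound 3 gives 1.36 nM, the second highest of the three numbers. Its nearest neighbour is compound 2, which gives 2.3 nM, a gap that is within the scatter. The furthest is compound 1, which gives 0.33 nM, a gap that lies beyond the scatter.

The new compound 4 `Cc1nc(Cl)ccc1OC[C@@H]1CCN1` differs from compound 3 by chloro in place of hydrogen on an aromatic carbon.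

Among the measured compounds shown here, only one measured step touches a chlorine on the shared core: a 1.7-fold lower number from compound 2 to compound 3 (0.23 log units; within the scatter). That step concerns an exchange of chloro for methyl, not the entry of chloro in place of hydrogen, and it sits on a different ring position, so it is only an indirect guide. For the measured compounds named here, no measured pair shows the present change itself. Going by the values given here, since the one available step lies within the scatter, no step beyond the scatter is expected in this assay from compound 3 to compound 4, in either direction, and the range of the estimate is kept wide to reflect the missing direct precedent.

For compound 4 the estimate in this assay is 1.1 nM, with a range from 0.4 nM to 3.5 nM, which corresponds to an expected step of a 1.2-fold lower number from compound 3 to compound 4 (0.09 log units; within the scatter).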

Compound 4, inhibition constant: 2.4 nM
Compound 4: middle estimate off by 2.2-fold (0.34 log units), on the low side, within the range that was stated.
By their numbers in this assay, from the lowest: compound 1; then compounds 3, 2 and 4 (each within the scatter of the next).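

In this assay, among the compounds shown here, chloro in place of hydrogen on the aromatic carbon next to the ring nitrogen, meta to a methyl group and para to a group of 6 heavy atoms, gives the first direct reading for this change (a 1.8-fold higher number from compound 3 to compound 4 (0.25 log units; within the scatter)). The earlier step (a 1.7-fold lower number from compound 2 to compound 3 (0.23 log units; within the scatter)) concerned an exchange of chloro for methyl at a different place, so it said nothing about whether this position, carrying only hydrogen in compound 3, could take a chlorine atom; the new step shows that it can, with no shift beyond the scatter when the methyl group is present. No supporting measurement bears on why the step has this size.

Still open, on these data alone, is whether this position would accept groups other than chloro, such as an amine, a methoxy group, a carboxylic acid or a longer chain, with a step of similarly small size. Also open, as far as these compounds go, is whether chloro at this position gives a comparable step in the absence of the methyl group, or on the core of compound 1, which carries a nitro group.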